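A Ring Swap at the End of a Side Chain

The source may hold more compounds than are shown below. What is called first, only, known or untested is meant among the compounds shown, and "the series" means these compounds.

Measured in a functional assay on U-87MG ATCC cells for cytotoxicity against U-87 MG (Homo sapiens), read by MTT assay, with a stated time of 72 h; a lower number here means a stronger inhibitor, a higher number a weaker inhibitor:
- compound 1 `COc1ncc(-c2ccc3nc(NC(=O)NCCN4CCCCC4)nn3c2)cc1NS(=O)(=O)c1ccc(F)cc1` gives 1080 nM
- compound 2 `COc1ncc(-c2ccc3nc(NC(=O)NCCN(C)C)nn3c2)cc1NS(=O)(=O)c1ccc(F)cc1` gives 980 nM
- compound 3 `COc1ncc(-c2ccc3nc(NC(=O)NCC(=O)N4CCOCC4)nn3c2)cc1NS(=O)(=O)c1ccc(F)cc1` gives 3260 nM

Still unmeasured is compound 4 `COc1ncc(-c2ccc3nc(NC(=O)NCCN4CCN(C)CC4)nn3c2)cc1NS(=O)(=O)c1ccc(F)cc1`.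

Compound 1, at 1080 nM, cannot be told apart from the lower of the other two values, while the remaining value is clearly higher. Compound 4 keeps the core of compound 1 and changes only the end of the chain: 4-methylpiperazin-1-yl in place of piperidin-1-yl on a saturated chain carbon, two bonds along the chain from an amide-type nitrogen. In short, 4-methylpiperazin-1-yl stands in place of piperidin-1-yl.

Among the compounds with values here, no measured step makes this exact swap. The closest is the replacement of that same ring by dimethylamino, at the same place, which gave a 1.1-fold lower number from compound 1 to compound 2 (0.04 log units; within the scatter). The change to (morpholin-4-yl)carbonyl alters more of the chain and gave a 3.0-fold higher number from compound 1 to compound 3 (0.48 log units; beyond the scatter), and likewise a 3.3-fold higher number from compound 2 to compound 3 (0.52 log units; beyond the scatter). So a change here can move the number modestly, but a plain amine swap has not. No step beyond the scatter is therefore expected in this assay.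

The estimate means an expected 1.0-fold higher number from compound 1 to compound 4 (0.01 log units; within the scatter). For compound 4 the expected value is 1100 nM, with an estimated range of 500 nM to 2500 nM.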

Compound 4, half-maximal inhibitory concentration: 760 nM
For compound 4 the middle estimate is 1.4-fold (0.16 log units) above the measured one; the measured number falls inside the stated range.
By their numbers in this assay, from the lowest: compounds 4, 2 and 1 (each within the scatter of the next); then compound 3.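

In this assay, 4-methylpiperazin-1-yl in place of piperidin-1-yl gives only a small shift (a 1.4-fold lower number from compound 1 to compound 4 (0.15 log units; within the scatter)), and the same holds for it in place of dimethylamino (a 1.3-fold lower number from compound 2 to compound 4 (0.11 log units; within the scatter)), so three different amine ends on this chain now cannot be told apart. Within the data shown here, compound 3 remains the exception, and the step to the new ring end (a 4.3-fold lower number from compound 3 to compound 4 (0.63 log units; beyond the scatter)) is the largest seen so far, which leaves the (morpholin-4-yl)carbonyl end as the only change here to move the number beyond the scatter. Nothing available offers a reason for these numbers.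

As far as these compounds go, whether the higher number of compound 3 belongs to its carbonyl or to its ring stays open, and a plain morpholin-4-yl on the same chain would separate the two. A longer chain carrying 4-methylpiperazin-1-yl is also an open case.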